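The compounds below may be only part of what the source reports. "The series", "measured", "known", "first", "only" and "open" are said of these compounds alone.

Among the compounds with values here, in an ADME assay on HT-29 cells (Homo sapiens) for cytotoxicity, read by MTT assay, with a stated time of 72 h (on this read-out lower numbers stand for stronger inhibition and higher numbers for weaker inhibition), compound 1 `COc1ccc(OC)c(C2=C(c3cc(OC)c(OC)c(OC)c3)C(=O)CC2O[SiH2]C(C)(C)C)c1` gives 5 ug/mL, the only exact number so far. Compound 2 `COc1ccc(OC)c(C2=C(c3cc(OC)c(OC)c(OC)c3)C(=O)CC2O)c1` lacks the silicon-bearing group on the oxygen and reads > 100 ug/mL, which is a limit of the assay and not a number. Within the data shown here, the single measured step, an at least 20-fold higher number from compound 1 to compound 2 (1.30 log units; beyond the scatter), is large and beyond the scatter, so the core of compound 1 with that group in place is the active form seen so far.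

Compound 3 `COc1ccc(C2=C(c3cc(OC)c(OC)c(OC)c3)C(=O)CC2O[SiH2]C(C)(C)C)cc1O` keeps the silicon-bearing group and changes a different part of the molecule: 3-hydroxy-4-methoxyphenyl in place of 2,5-dimethoxyphenyl on a double-bonded ring carbon. The measured step sits at another place, so it bears on this change only indirectly: the group carried by compound 1, which gives 5 ug/mL, is still there. Among the measured compounds shown here, no measured step tests the new ring, so the size of this step is uncertain. A modest move towards a lower number is expected, a 3.3-fold lower number from compound 1 to compound 3 (0.52 log units; beyond the scatter), with the range left wide. The estimate for compound 3 is 1.5 ug/mL, expected to lie between 0.05 ug/mL and 20 ug/mL.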

Compound 3, half-maximal inhibitory concentration: 38 ug/mL
Beside the measured number, compound 3's estimate is 25-fold (1.40 log units) below it; the measured number lies above the stated range.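

Within the data shown here, the first step showed only that the silicon-bearing group on the oxygen matters; this one shows that the aromatic ring on the double-bonded ring carbon matters too. With that group kept, replacing 2,5-dimethoxyphenyl by 3-hydroxy-4-methoxyphenyl gives in this assay a 7.6-fold higher number from compound 1 to compound 3 (0.88 log units; beyond the scatter), so the silicon-bearing group alone does not set the level of the number, and of these two rings the 2,5-dimethoxyphenyl goes with the lower one. Among these compounds, the swap alters both the kind of groups on the ring and where they stand, and nothing measured so far explains the shift or separates these two parts of the change.

The compounds shown leave open whether the higher number follows from the hydroxy group itself or from the new arrangement on the ring, a question that a ring with a single methoxy group, or with an amine or a fluorine atom in place of the hydroxy group, would bear on. They also leave open whether a silicon-bearing group is needed at all on the oxygen, or whether an acetyl group or a longer carbon chain there would serve as well.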